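This account rests on a few compounds, and the source may have more. Where it says the series, first, only, none or still open, it means among the compounds named here.

Measured so far:
- compound 1, `CCCCCCCCCCCCC/C=C/[C@@H](O)[C@H](CO)NC(C)=O`: 26000 nM
- compound 2, `CCCCCCCCc1ccc(/C=C/C(=O)[C@H](CO)NC(C)=O)cc1`: no result reported

Compound 1 was tested in a functional assay on HL-60 cells (Homo sapiens) for antiproliferative activity, read by resazurin assay, with a stated time of 24 h (on this read-out higher numbers stand for weaker inhibition and lower numbers for stronger inhibition), where compound 1 gives 26000 nM. Compound 2 carries an octyl group on a six-membered aromatic ring of carbon only; in this assay compound 2 has no result reported, so there is no single number where compound 2 stands; the only anchor in this set is compound 1, which has a different shape from compound 2 and therefore gives no direct comparison.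

Compound 3, `CC(=O)N[C@@H](CO)C(=O)/C=C/c1ccc(-c2ccccc2)cc1`, is the next compound to be measured. It differs from compound 2 in one place: phenyl in place of octyl on an aromatic carbon. Among the compounds with values here, no measured pair in this set shows what such a change does. Without an anchor for compound 2, the step from compound 2 to compound 3 in this assay cannot be sized from data; the expectation is a change that stays within the scatter, in no particular direction.

The value for compound 3 in this assay is therefore estimated near 20000 nM, with a broad range from 5000 nM to 80000 nM, resting only on the weak inhibition shown by compound 1 at 26000 nM.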

Compound 3, half-maximal inhibitory concentration: 50000 nM
Compound 3: middle estimate off by 2.5-fold (0.40 log units), on the low side; low and high end bracket the measured number.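

In this assay, within the data shown here, compound 3 gives 50000 nM but yields no new step, as compound 2 has no single number to pair with it and compound 1 differs in more than one place. Nothing shown offers an explanation for this value. As far as these compounds go, what replacing octyl with phenyl does to the activity remains open.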